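The source may report more compounds than this note shows. Statements on the series, on what has been measured and on what is new or still open speak of the compounds shown alone.

Of the compounds shown here, two have been measured in an assay on HEK293 cells for displacement of a labelled ligand from Melanocortin receptor 4 (Homo sapiens); on this read-out higher numbers stand for weaker inhibition and lower numbers for stronger inhibition. Compound 1 `CC(C)[C@H](NC(=O)CCN(C)C)c1cccc(F)c1N1CCN(C(=O)[C@@H]2CN(C(C)C)C[C@H]2c2ccc(C(F)(F)F)c(F)c2)CC1` gives 51 nM, the higher of the two numbers. Compound 2 `CNCC(=O)N[C@H](c1cc(C)ccc1N1CCN(C(=O)[C@@H]2CN(C3CCOCC3)C[C@H]2c2ccc(Cl)cc2)CC1)C(C)C` differs from compound 1 in several places at once. In this assay compound 2 gives 2.1 nM, a number well below that of compound 1 and outside the usual scatter; because the two structures differ in more than one place, the pair shows only that much and cannot be traced to any single change. Compound 3 `CC(C)[C@H](NC(=O)CCN(C)C)c1cccc(F)c1N1CCN(C(=O)[C@@H]2CN(C(C)C)C[C@H]2c2cccc(F)c2)CC1` has not yet been measured. It differs from compound 1 in one place: hydrogen in place of trifluoromethyl on an aromatic carbon. Within the data shown here, no measured pair here isolates this kind of change, so the data give no direct guide. The expected step is a 2.4-fold higher number from compound 1 to compound 3 (0.37 log units; beyond the scatter), small and toward a higher number, close to the edge of the scatter. On that basis compound 3 is estimated to give 120 nM in this assay, with a range from 40 nM to 400 nM.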

Compound 3, inhibition constant: 560 nM
Estimate against measurement, compound 3: 4.7-fold (0.67 log units) below; the whole stated range lies below it.
By their numbers in this assay, from the lowest: compound 2; then compound 1; then compound 3.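

Among these compounds, this is the first comparison here that differs in one place only. In this assay, going from the 3-fluoro-4-(trifluoromethyl)phenyl group to 3-fluorophenyl gives an 11-fold higher number from compound 1 to compound 3 (1.04 log units; beyond the scatter) and leaves the rest of the structure unchanged, so this aromatic carbon clearly matters: with trifluoromethyl there, inhibition is much stronger than with hydrogen. Nothing measured here explains why the number moves so far.

The compounds shown leave open whether another group on this carbon, such as methoxy or a nitrile, would match trifluoromethyl, or whether trifluoromethyl is needed specifically. They also leave open whether the same change would shift the number as far in a structure carrying the other differences seen in compound 2.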